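Swapping an Ether Link for an Amine Link

A few compounds are considered here, and "the series" means these few. Any claim that something is new, unique, unknown or untested is made for them only; others in the source may bear on it.

Measured compounds:
Compound 1, `COc1cc(Nc2ncccc2-c2n[nH]c(Nc3ccc4c(c3)OCCO4)n2)cc(OC)c1`, in a functional assay on A-431 cells (Homo sapiens), tested at 0.1 uM (on this read-out lower numbers stand for less inhibition and higher numbers for more inhibition at the one concentration tested (going by the name of the read-out)), gives 83%.
Compound 2, `COc1cc(OC)cc(Oc2ncccc2-c2n[nH]c(Nc3ccc4c(c3)OCCO4)n2)c1`, in this assay gives 89%.
Compound 3, `COc1cc(OC)cc(Oc2ncncc2-c2n[nH]c(Nc3ccc4c(c3)OCCO4)n2)c1`, in this assay gives 83%.

Compound 2 and compound 1 share one core and differ only in the group on it: (3,5-dimethoxyphenyl)amino in place of 3,5-dimethoxyphenoxy on an aromatic carbon. That exchange produced a number 6 percentage points lower from compound 2 to compound 1 (within the scatter). Compound 3 carries the same 3,5-dimethoxyphenoxy group as compound 2 but on a different core; how the two cores differ is not broken down here. Compound 3 stands level with compound 1 at the digits shown, and its gap to compound 2 lies within the scatter, so the three measured compounds cannot be separated from one another.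

Compound 4, `COc1cc(Nc2ncncc2-c2n[nH]c(Nc3ccc4c(c3)OCCO4)n2)cc(OC)c1`, is compound 3 with the same exchange: (3,5-dimethoxyphenyl)amino in place of 3,5-dimethoxyphenoxy on an aromatic carbon. The surroundings are not identical. In the earlier pair the change sits on a six-membered aromatic ring with 1 nitrogen, next to the ring nitrogen, ortho to a large group; in compound 4 it sits on a ring with 2 nitrogen, next to the ring nitrogen, ortho to a large group, opposite the ring nitrogen. It is therefore the same kind of change, not the same change.

The step is expected to be a number 4 percentage points lower from compound 3 to compound 4 (within the scatter), which rests on the earlier step of a number 6 percentage points lower from compound 2 to compound 1 (within the scatter) and on compound 3 giving 83%. Compound 4 is thus estimated to give 79% in this assay, with a range from 66% to 90%.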

Compound 4, a percentage reported as inhibition, at one concentration (the size of the read-out at that concentration, not a potency): 68%
Estimate against measurement, compound 4: 11 percentage points above; the range from low to high includes it.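

In this assay, exchanging 3,5-dimethoxyphenoxy for (3,5-dimethoxyphenyl)amino on the second core gives a number 15 percentage points lower from compound 3 to compound 4 (beyond the scatter). Set beside the same exchange on the first core, the two steps compare as follows: the same change on two cores in this assay, a number 6 percentage points lower (within the scatter) from compound 2 to compound 1 and a number 15 percentage points lower (beyond the scatter) from compound 3 to compound 4, 9 percentage points apart, within the scatter of two such steps Only the step on the second core can be read as a real loss of inhibition, yet the gap between the two steps is no larger than the scatter, so these compounds do not show that the core alters the effect of the exchange, and they do not show that the effect is the same on both cores either.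

What the compounds shown leave open is how other links in this place would compare with the oxygen and the amine hydrogen-bearing nitrogen, for example a sulfur atom, a methylene group or an N-methyl amine. Also open is whether the exchange would behave the same way on a third core, and how any of these compounds would rank in potency, since each number here is the inhibition at a single concentration.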